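Carboxy in Place of Trifluoromethyl: Expecting Compound 3

This account rests on a few compounds, and the source may have more. Where it says the series, first, only, none or still open, it means among the compounds named here.

Compound 1 `COc1ccc(-c2cc(-c3ccc(S(N)(=O)=O)cc3)cnc2N)cn1` and compound 2 `COc1ccc(-c2cc(-c3ccc(C(F)(F)F)cc3)cnc2N)cn1` share one core and differ only in the group carried on the outer benzene ring. Both were tested in an in vitro ADME assay on microsomes from liver (Homo sapiens) for metabolic stability; a higher number here means that the compound lasts longer, a lower number that the compound disappears faster. In this assay compound 1 reaches only a limit, > 4.16 h, which is not a number. In this assay compound 2 gives 4.75 h. Among the measured compounds shown here, compound 2 thus holds the only real number in the set, the other entry being a limit. The step that the limit leaves unreadable from compound 1 to compound 2 cannot be sized because the limit of > 4.16 h in this assay, at which 1 of the 2 values shown sits, hides where compound 1 truly sits.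

Compound 3 `COc1ccc(-c2cc(-c3ccc(C(=O)O)cc3)cnc2N)cn1` has not yet been measured. It differs from compound 2 in one place: carboxy in place of trifluoromethyl on an aromatic carbon. For the measured compounds named here, the only measured step, from compound 1 to compound 2, gives no size, so nothing measured tells how large a change to expect, or in which direction. Compound 3 is therefore expected to give about 4 h in this assay, within a wide range from 1.5 h to 10 h. The expected step of a 1.2-fold lower number from compound 2 to compound 3 (0.07 log units; within the scatter) is thus a small one, with a fair chance that this assay again reports only a limit.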

Compound 3, half-life: > 4.16 h
Compound 3: a limit, no number (the forecaster's own chance of this, stated with the estimate: 40%); middle value at least 1.0-fold (0.01 log units) away from the limit.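

No new step can be read between compound 3 and either compound 2 or compound 1 in this assay, because compound 1 and compound 3 each reach only a limit, not a number: the limit of > 4.16 h in this assay, at which 2 of the 3 values shown sit.

The compounds shown leave open where compound 1 and compound 3 truly sit, and so whether exchanging sulfamoyl, trifluoromethyl and carboxy changes the half-life at all.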